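Methyl on the phenol oxygen: compound 2 to compound 4

A few compounds are considered here, and "the series" means these few. Any claim that something is new, unique, unknown or untested is made for them only; others in the source may bear on it.

Measured so far:
Compound 1, `O=C(Nc1cccc(-n2cc(-c3ccncc3)c(-c3cc(O)cc(Cl)c3)n2)c1)Nc1ccc(Cl)c(C(F)(F)F)c1`: 34.6%
Compound 2, `O=C(Nc1cccc(-n2cc(-c3ccncc3)c(-c3cc(O)cc(Cl)c3)n2)c1)Nc1ccc(Cl)c(Cl)c1`: 14.9%
Compound 3, `COc1cc(Cl)cc(-c2nn(-c3cccc(NC(=O)Nc4cc(C(F)(F)F)cc(C(F)(F)F)c4)c3)cc2-c2ccncc2)c1`: 9.32%

For the measured compounds named here, in a functional assay on SN12C cells (Homo sapiens) for inhibition, read by sulforhodamine B assay, with a stated time of 48 h, tested at 10 uM (a higher number here means a weaker effect of the compound at the concentration tested, a lower number a stronger effect), compound 2 gives 14.9%, the second highest of the three numbers; compound 3 gives 9.32%, within the scatter of compound 2, while compound 1 stands beyond the scatter above it, the one measured step being a number 19.7 percentage points lower from compound 1 to compound 2 (beyond the scatter).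

Compound 4, `COc1cc(Cl)cc(-c2nn(-c3cccc(NC(=O)Nc4ccc(Cl)c(Cl)c4)c3)cc2-c2ccncc2)c1`, differs from compound 2 by methyl in place of hydrogen on an oxygen on an aromatic ring. Going by the values given here, no measured step covers this change; the only step known concerns the urea aryl, not the phenol. Compound 3 carries the methoxy group but also a different urea aryl, so its value shows no isolated effect of the methyl.

With nothing bearing on the step, no change beyond the scatter is expected: compound 4 is estimated at 13%, between 3% and 28%, the expected step being a number 1.9 percentage points lower from compound 2 to compound 4 (within the scatter).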

Compound 4, a percentage reported as activity, at one concentration (the size of the read-out at that concentration, not a potency): 15.5%
The estimate for compound 4 lay 2.5 percentage points below the measured number, within the range that was stated.
By their numbers in this assay, from the lowest: compounds 3, 2 and 4 (each within the scatter of the next); then compound 1.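

In this assay the change from hydroxy to methoxy gives a number 0.6 percentage points higher from compound 2 to compound 4 (within the scatter) and so leaves compound 2 and compound 4 indistinguishable. With this urea aryl held constant, the hydrogen on this oxygen is therefore not needed for the effect seen at the concentration tested, which compound 3 could not show, as it also differs in the urea aryl. Nothing measured here explains the result.

From the compounds shown here alone, it remains open whether an ethyl or longer chain on this oxygen, or an amine in place of the hydroxy, would read the same. Also open, going by these compounds, is whether the methyl step would read the same with the urea aryl of compound 1.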